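A few compounds are considered here, and "the series" means these few. Any claim that something is new, unique, unknown or untested is made for them only; others in the source may bear on it.

Series note on the shared core of compound 1 `CCc1cnc(N2CCC(c3nc(COc4ccc(/C=C5\CC(=O)N(CC6CCOCC6)C5=O)cc4F)cs3)CC2)nc1`, whose single numbered read-out so far comes from a functional assay on cells for agonist activity at Glucose-dependent insulinotropic receptor (Homo sapiens), read by a luciferase reporter, with a stated time of 6 h (on this read-out lower numbers stand for an effect already at smaller amounts and higher numbers for an effect only at larger amounts of compound), where compound 1 gives 240 nM. This is the only figure in the set: compound 2 `O=C(O)CCc1cnc(N2CCC(c3nc(COc4ccc(-n5cnnn5)cc4)cs3)CC2)nc1` has "not determined" (no result reported) in this assay, and compound 3 `NCCOCCOCCOCCNC(=O)CCc1cnc(N2CCC(c3nc(COc4ccc(-n5cnnn5)cc4)cs3)CC2)nc1` has "not determined" (no result reported) there; both carry the tetrazolyl phenoxy arm in place of the benzylidene imide, so compound 1 stands alone and nothing can be said about their relation to it beyond the absence of a number.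

The open question is compound 4 `CCc1cnc(N2CCC(c3nc(COc4ccc(/C=C5\CC(=O)NC5=O)cc4F)cs3)CC2)nc1`, which keeps the benzylidene imide and the fluorine on the aromatic ring but strips the ring nitrogen: hydrogen in place of (oxan-4-yl)methyl on an amide-type nitrogen in a ring.

For the measured compounds named here, no measured pair in the set differs in just one place, so the size of this step cannot be read from a neighbour. The expectation is a shift in this assay from compound 1 to compound 4 of modest size, toward higher concentration rather than lower, on the general ground that a substituent of this size on the imide nitrogen tends to matter; an expected step of a 2.5-fold higher number from compound 1 to compound 4 (0.40 log units; beyond the scatter) is assumed, with a range wide enough to include no change at all. For compound 4 the estimated value is 600 nM, expected to fall between 180 nM and 2500 nM.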

Compound 4, half-maximal effective concentration: 49 nM
Compound 4: the middle estimate sits 12-fold (1.09 log units) above what was measured; the whole stated range lies above it.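

In this assay, for the compounds shown here, hydrogen in place of (oxan-4-yl)methyl on an amide-type nitrogen in a ring gives a 4.9-fold lower number from compound 1 to compound 4 (0.69 log units; beyond the scatter) and provides the first reading at this position, which the single number for compound 1 could not supply. The oxan-4-yl ring and its methyl link are therefore not required for agonist activity in this read-out, and of the two states shown at this nitrogen, the unsubstituted one in compound 4 gives the lower number. The compounds shown offer nothing that explains this step.

On these data alone, only these two states of the imide nitrogen can be compared, so it remains open whether the trend is gradual or whether a small methyl, a longer alkyl chain, or a chain ending in an amine or a carboxylic acid would stay near compound 4 or return toward compound 1. Steps involving compound 2 and compound 3 cannot be read, which leaves the tetrazolyl phenoxy arm unconnected to either imide compound in this series.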